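From Fluoro to Nitro in a Small Cytotoxic Series

A few compounds are considered here, and "the series" means these few. Any claim that something is new, unique, unknown or untested is made for them only; others in the source may bear on it.

Compound 1 `C/C(=N/NC(=S)Nc1ccc([N+](=O)[O-])cc1)c1ccccn1`: 52 nM
Compound 2 `CC(=NNC(=S)Nc1ccc(Cl)cc1)c1ccccn1`: 8.5 nM
Compound 3 `CC(=NNC(=S)Nc1ccc(F)cc1)c1ccccn1`: 1.2 nM

All three values come from a functional assay on MCF7 cells (Homo sapiens) for cytotoxicity, read by MTT assay, with a stated time of 48 h; on this read-out lower numbers stand for stronger inhibition and higher numbers for weaker inhibition. Compound 3 has the lowest number of the three, which makes it the strongest inhibitor measured so far. The next structure, compound 4 `CC(=NNC(=S)Nc1ccc([N+](=O)[O-])cc1)c1ccccn1`, changes a single group of compound 3: nitro in place of fluoro on an aromatic carbon. In words, this is nitro in place of fluoro on an aromatic carbon, para to a large group.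

One measured step involves the same place: a 7.1-fold lower number from compound 2 to compound 3 (0.85 log units; beyond the scatter). It shows that a swap there can move the number, but it says nothing directly about nitro. A closer guide is available, since the drawing of compound 4 has the same atoms as the drawing of compound 1 and only leaves the geometry of one double bond unfixed. That nitro compound, compound 1, gives 52 nM. A rise beyond the scatter is therefore expected in this assay, meaning weaker inhibition. The estimated change is a 38-fold higher number from compound 3 to compound 4 (1.57 log units; beyond the scatter). For compound 4 the estimated value is 45 nM, with an expected range of 12 nM to 160 nM.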

Compound 4, half-maximal inhibitory concentration: 52 nM
Beside the measured number, compound 4's estimate is 1.2-fold (0.06 log units) below it; the range from low to high includes it.
By their numbers in this assay, from the lowest: compound 3; then compound 2; then compounds 1 and 4 (each within the scatter of the next).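

The nitro group now has a place beside both halogens on this aromatic carbon. In this assay, replacing fluoro with nitro gives a 43-fold higher number from compound 3 to compound 4 (1.64 log units; beyond the scatter), and replacing chloro with nitro gives a 6.1-fold higher number from compound 2 to compound 4 (0.79 log units; beyond the scatter), so among the three groups shown, the nitro compounds carry the highest numbers. The drawn geometry of the double bond shows no effect on the number, with no change at the digits printed from compound 1 to compound 4 (within the scatter), and the two entries are separated by a single point of drawing: the fact that one of compounds 1 and 4 is drawn with a defined configuration and the other without, at the place where they differ

Compound 4 has no stated geometry, so these numbers cannot show whether the two forms of that double bond would differ. From the compounds shown here alone, how an amine or a methoxy group on the same aromatic carbon would compare with fluoro, chloro and nitro also remains open.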